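This account rests on a few compounds, and the source may have more. Where it says the series, first, only, none or still open, it means among the compounds named here.

Measured so far:
compound 1, `CCn1cc(-c2nc3ccccc3[nH]2)c(=O)c2cc(F)c(N3CCNCC3)cc21`: > 10000 nM
compound 2, `CCn1cc(-c2nc3ccccc3[nH]2)c(=O)c2cc(F)c(N3CCNCC3)nc21`: 6400 nM

Both compounds were tested in a functional assay on HeLa cells (Homo sapiens) for cytotoxicity, read by sulforhodamine B assay, with a stated time of 48 h; a higher number here means a weaker inhibitor of growth, a lower number a stronger inhibitor of growth. Compound 1 gives only a limit there, > 10000 nM, so no exact number is known for it; this is recorded as the limit of > 10000 nM in this assay, at which 1 of the 2 values shown sits. Compound 2 gives a measured value of 6400 nM in this assay. Within the data shown here, no counted step joins the two, so the pair shows only that compound 1 sits at the limit while compound 2 sits at a number not far from it.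

Compound 3, `CCn1cc(-c2nc3ccc(Cl)cc3[nH]2)c(=O)c2cc(F)c(N3CCNCC3)cc21`, is not yet measured. It differs from compound 1 in one place: chloro in place of hydrogen on an aromatic carbon. The chloro enters on an aromatic carbon of a six-membered aromatic ring of carbon only, part of a fused system of two rings, so that the 1H-benzimidazol-2-yl becomes a 6-chloro-1H-benzimidazol-2-yl.

Among the measured compounds shown here, no measured step of this kind is at hand, so its size cannot be read off. The expected step that the limit leaves unreadable from compound 1 to compound 3 is small, within the usual scatter. Compound 3 is therefore estimated at 12000 nM in this assay, with a range from 4000 nM to 40000 nM, and it may again yield only a limit.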

Compound 3, concentration for 50% growth inhibition: 1200 nM
For compound 3 the middle estimate is 10-fold (1.00 log units) above the measured one, and the stated range ends above it.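

In this assay, replacing hydrogen with chloro, which turns the 1H-benzimidazol-2-yl into a 6-chloro-1H-benzimidazol-2-yl, gives an at least 8.3-fold lower number from compound 1 to compound 3 (0.92 log units; beyond the scatter). This shows that the aromatic carbon carrying the chloro is not a silent position, since one added heavy atom there is enough to bring growth inhibition from a limit to a measured number, something compound 1 and compound 2 could not show with hydrogen at that carbon. The step gives only a minimum size, and its full size stays unknown because compound 1 has a limit rather than a number: the limit of > 10000 nM in this assay, at which 1 of the 3 values shown sits.

The compounds shown leave open whether this gain belongs to chloro itself or whether a fluoro, methyl or methoxy group on the same carbon would do as much, and a single pair cannot say which property of the chloro matters. They also leave open whether chloro would act in the same way on the core of compound 2, or on another carbon of the same six-membered ring.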